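The source may report more compounds than this note shows. Statements on the series, on what has been measured and on what is new or still open speak of the compounds shown alone.

Two compounds of this series carry a measured number in a functional assay on the whole organism with Mus musculus as the target, in the maximal electroshock model, with a stated time of 4 h; on this read-out lower numbers stand for an effect already at smaller amounts and higher numbers for an effect only at larger amounts of compound. Compound 1, `O=C(Cn1ccc2ccccc21)Nc1nc2ccc(Cl)cc2s1`, gives 300 mg/kg, and compound 2, `CC(C)(C)NCC(=O)Nc1nc2ccc(Cl)cc2s1`, gives 100 mg/kg; compound 2 thus stands at the lowest of the two numbers, compound 1 being its nearest neighbour with a higher number, and that gap lies beyond the usual scatter. The step from compound 2 to compound 3, `O=C(CN1CCCCC1)Nc1nc2ccc(Cl)cc2s1`, concerns one place: piperidin-1-yl in place of (tert-butyl)amino on a saturated chain carbon bound to a carbonyl carbon. For the measured compounds named here, no measured pair shows this kind of change, so the direction of the step cannot be read from the data; what is known is only that compound 2 sits at the lower end. For compound 3 a change of no change at the digits printed from compound 2 to compound 3 (within the scatter) is expected, that is, no shift beyond the scatter, with the value estimated at 100 mg/kg, ranging between 50 mg/kg and 300 mg/kg.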

Compound 3, minimum effective dose: 100 mg/kg
The estimate for compound 3 equals the measured number at the digits printed; measured number inside the range.
By their numbers in this assay, from the lowest: compounds 2 and 3 (each within the scatter of the next); then compound 1.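

At the saturated chain carbon bound to a carbonyl carbon, this assay now gives its first reading of a single change, and piperidin-1-yl in place of (tert-butyl)amino gives no change at the digits printed from compound 2 to compound 3 (within the scatter). In this pair, the change from 1 hydrogen-bond donor to 0 and from no ring to one six-membered non-aromatic ring leaves the read-out within the scatter, so neither the donor nor the open form of the amine is required here. No measurement in hand explains why the two groups read alike.

From the compounds shown here alone, how a morpholin-4-yl group, a dimethylamino group or a longer chain would read at this place remains open. Also open, going by these compounds, is whether the pair would still read alike with a fluoro group in place of the chloro group on the shared core.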